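A few compounds are considered here, and "the series" means these few. Any claim that something is new, unique, unknown or untested is made for them only; others in the source may bear on it.

Two compounds share one core and differ only in the group carried on a sulfur. Compound 1 `Cn1c(-c2ccc(NC(=O)CSc3nc4cc(Cl)ccc4o3)cc2)nc(-c2ccccc2)c1-c1ccccc1` gives 2.5% in a functional assay on MCF7 cells (Homo sapiens) for cytotoxicity, read by MTT assay, with a stated time of 24 h, tested at 1.6 ug/mL; on this read-out lower numbers stand for a weaker effect and higher numbers for a stronger effect at the one concentration tested. Going by the values given here, compound 2 `Cc1nnc(SCC(=O)Nc2ccc(-c3nc(-c4ccccc4)c(-c4ccccc4)n3C)cc2)s1` gives 37.5% in this assay, the higher of the two numbers, and the one measured step, a number 35 percentage points higher from compound 1 to compound 2 (beyond the scatter), shows how strongly the group on that sulfur can move the read-out. Compound 3 `Cn1ccnc1SCC(=O)Nc1ccc(-c2nc(-c3ccccc3)c(-c3ccccc3)n2C)cc1` changes the same position again: 1-methyl-1H-imidazol-2-yl in place of 5-methyl-1,3,4-thiadiazol-2-yl on a sulfur. Among the compounds with values here, only the step from compound 1 to compound 2 bears on this, and it was large, but it compared different groups, so it tells the size of what such a swap can do rather than its direction here. Compound 3 is therefore expected to give about 20%, within 2% to 45%. That would be an expected step of a number 17.5 percentage points lower from compound 2 to compound 3 (beyond the scatter), a loss but with wide uncertainty.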

Compound 3, a percentage reported as activity, at one concentration (the size of the read-out at that concentration, not a potency): 17.5%
For compound 3 the middle estimate is 2.5 percentage points above the measured one; the range from low to high includes it.
By their numbers in this assay, from the lowest: compound 1; then compound 3; then compound 2.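

In this assay, 1-methyl-1H-imidazol-2-yl in place of 5-methyl-1,3,4-thiadiazol-2-yl on the sulfur gives a number 20 percentage points lower from compound 2 to compound 3 (beyond the scatter), so two five-membered aromatic rings with the same count of heavy atoms are not interchangeable here. The imidazole group still compares well with 5-chloro-1,3-benzoxazol-2-yl, giving a number 15 percentage points higher from compound 1 to compound 3 (beyond the scatter), which places compound 3 in the middle of the three and shows that this position can give intermediate read-outs as well as two extremes. Nothing available explains why these groups differ.

From the compounds shown here alone, whether this position needs an aromatic ring at all stays open, since a butyl chain or a carboxylic acid on the sulfur could tell that apart. Going by these compounds, each number also comes from a single concentration, so how the three compounds rank in potency remains unknown.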